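Chain lengthening toward the hydroxycarbamoyl group

The compounds below may be only part of what the source reports. "The series", "measured", "known", "first", "only" and "open" are said of these compounds alone.

Compound 1 `O=C(O)c1ccc2c(c1)no[n+]2[O-]`: "not determined" (no result reported) in a functional assay on HeLa cells (Homo sapiens) for inhibition, read by MTT assay, with a stated time of 48 h; on this read-out lower numbers stand for stronger inhibition and higher numbers for weaker inhibition.
Compound 2 `O=C(CCCOC(=O)c1ccc2c(c1)no[n+]2[O-])NO`: 17000 nM in this assay.
Compound 3 `O=C(CCCCOC(=O)c1ccc2c(c1)no[n+]2[O-])NO`: 15900 nM in this assay.

Compound 3 holds the lowest of the two numbers measured, with compound 2 as its nearest neighbour; the step of a 1.1-fold lower number from compound 2 to compound 3 (0.03 log units; within the scatter) lies within the scatter, and compound 1 has no number. Compound 4 `O=C(CCCCCCOC(=O)c1ccc2c(c1)no[n+]2[O-])NO` differs from compound 3 by 2-(hydroxycarbamoyl)ethyl in place of hydroxycarbamoyl on a saturated chain carbon, four bonds along the chain from an oxygen next to a carbonyl group. Among the measured compounds shown here, the only measured step that bears on this change is the chain extension a 1.1-fold lower number from compound 2 to compound 3 (0.03 log units; within the scatter), which was within the scatter. A further extension of the same kind is therefore expected to give a step no larger than the scatter, a 1.1-fold lower number from compound 3 to compound 4 (0.06 log units; within the scatter). Compound 4 is estimated at 14000 nM, with a range from 7000 nM to 28000 nM.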

Compound 4, half-maximal inhibitory concentration: 9180 nM
Compound 4: the middle estimate sits 1.5-fold (0.18 log units) above what was measured; low and high end bracket the measured number.
By their numbers in this assay, from the lowest: compounds 4, 3 and 2 (each within the scatter of the next).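

In this assay the step (a 1.7-fold lower number from compound 3 to compound 4 (0.24 log units; within the scatter)) stays within the scatter, and so does the widest change shown, 3-(hydroxycarbamoyl)propyl in place of hydroxycarbamoyl (a 1.9-fold lower number from compound 2 to compound 4 (0.27 log units; within the scatter)). The chain lengths of compound 2, compound 3 and compound 4 therefore cannot be told apart on this read-out, now across the whole span shown rather than a single step. No measurement given here accounts for these numbers.

Open, from the compounds shown here alone, is whether a longer chain than in compound 4 would take the number beyond the scatter. Also open, going by these compounds, is whether an amide or a carboxylic acid at the chain end, in place of the hydroxycarbamoyl group, would change it.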